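A few compounds are considered here, and "the series" means these few. Any claim that something is new, unique, unknown or untested is made for them only; others in the source may bear on it.

Series notes. Compound 2 `COC(=O)/C=C/c1cccc(N(Cc2ccc(-c3ccc(C(C)(C)C)cc3)cc2)C(=O)C2CCCCC2)c1` carries a 4-(tert-butyl)phenyl group; in an assay on isolated protein with Bile acid receptor (Homo sapiens) as the target (a higher number here means that more compound is needed for the effect, a lower number that less compound is needed), compound 2 gives 132 nM, the highest of the two numbers here. Compound 1 `COC(=O)/C=C/c1cccc(N(Cc2ccc(-c3ccc(N(C)C)cc3)cc2)C(=O)C(C)C)c1` gives 57 nM in this assay, a lower number than compound 2 and a gap beyond the scatter. Compound 3 `CC(C)(C)OC(=O)/C=C/c1cccc(N(Cc2ccc(CCC(=O)OC(C)(C)C)cc2)C(=O)C2CCCCC2)c1` reaches only a limit of the assay, > 1000 nM in this assay, a case of the limit of > 1000 nM in this assay, at which 1 of the 3 values shown sits. Compound 4 `COC(=O)/C=C/c1cccc(N(Cc2ccc(-c3cc(Cl)ccc3OC)cc2)C(=O)C2CCCCC2)c1` is not yet measured; against compound 2 the change is 5-chloro-2-methoxyphenyl in place of 4-(tert-butyl)phenyl on an aromatic carbon. Going by the values given here, with no measured pair of this kind to lean on, only a small step from compound 2 to compound 4 is expected, if any beyond the scatter, more likely upward than downward. Compound 4 is therefore estimated at 200 nM in this assay, within 60 nM to 700 nM, an expected step of a 1.5-fold higher number from compound 2 to compound 4 (0.18 log units; within the scatter).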

Compound 4, half-maximal effective concentration: 233 nM
The estimate for compound 4 lay 1.2-fold (0.07 log units) below the measured number, within the range that was stated.
By their numbers in this assay, from the lowest: compound 1; then compounds 2 and 4 (each within the scatter of the next). At a limit, above all of these: compound 3.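

Going by these compounds alone, this is the first pair that differs in one place: on an aromatic carbon para to a large group, 5-chloro-2-methoxyphenyl in place of 4-(tert-butyl)phenyl gives a 1.8-fold higher number from compound 2 to compound 4 (0.25 log units; within the scatter) in this assay. The entering group brings a hydrogen-bond acceptor, and the two compounds are not separated by this read-out. No measurement shown offers a cause for this step. Open, from the compounds shown here alone, is whether a carboxylic acid or a primary amide on this ring would stay in the same range.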